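Swapping the chain end on a fused two-ring core

The source may report more compounds than this note shows. Statements on the series, on what has been measured and on what is new or still open speak of the compounds shown alone.

Measured compounds:
- compound 1, `COc1cc(/C=C/C(=O)c2cc(-c3cc(OC)c(OC)c(OC)c3)n3nc(-c4ccccc4)cc3n2)cc(OC)c1OC`, 17900 nM
- compound 2, `COc1ccc(-c2cc(/C=C/C(=O)c3ccc(Cl)cc3)nc3cc(-c4ccccc4)nn23)cc1OC`, 21300 nM
- compound 3, `COc1cc(-c2cc(C(=O)/C=C/c3ccc(C)cc3)nc3cc(-c4ccccc4)nn23)cc(OC)c1OC`, 21900 nM

All three were tested in a functional assay on DU-145 cells (Homo sapiens) for antiproliferative activity, read by MTT assay, with a stated time of 24 h; a higher number here means a weaker inhibitor, a lower number a stronger inhibitor. Compound 3 stands among the others rather than apart from them: its gap to compound 2 and its gap to compound 1 are both within the scatter, so no order among the three can be read from these numbers.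

Compound 4, `COc1cc(-c2cc(/C=C/C(=O)c3ccc(Cl)cc3)nc3cc(-c4ccccc4)nn23)cc(OC)c1OC`, is not yet measured. It differs from compound 3 in one place: 2-((4-chlorophenyl)carbonyl)ethenyl in place of (2-(4-methylphenyl)ethenyl)carbonyl on an aromatic carbon. Among the compounds with values here, the only measured step that touches the same chain is a 1.2-fold higher number from compound 1 to compound 3 (0.09 log units; within the scatter), a change of the ring at the far end of the chain that left the number essentially where it was. Compound 2 carries the same chain as compound 4 on a core that is not the same, and its value sits close to that of compound 3. Nothing here points to a shift beyond the scatter, so the expected step of a 1.0-fold lower number from compound 3 to compound 4 (0.02 log units; within the scatter) is small. Compound 4 is therefore estimated at 21000 nM, within 9000 nM to 48000 nM.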

Compound 4, half-maximal inhibitory concentration: 29300 nM
Compound 4: the middle estimate sits 1.4-fold (0.14 log units) below what was measured; low and high end bracket the measured number.
By their numbers in this assay, from the lowest: compounds 1, 2, 3 and 4 (each within the scatter of the next).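

In this assay, the whole chain on this aromatic carbon can be exchanged, 2-((4-chlorophenyl)carbonyl)ethenyl in place of (2-(4-methylphenyl)ethenyl)carbonyl, and the outcome is a 1.3-fold higher number from compound 3 to compound 4 (0.13 log units; within the scatter) on the same core. Methoxy in place of hydrogen on an aromatic carbon gives a 1.4-fold higher number from compound 2 to compound 4 (0.14 log units; within the scatter) with the chain held the same, so neither exchange can be told apart from repeat-measurement noise. No accompanying measurement offers an explanation for these numbers.

The exchange from compound 3 to compound 4 alters the end ring's substituent and the chain's orientation together, so the contribution of each remains unresolved. From the compounds shown here alone, whether an amine or a carboxylic acid on the end ring, or a longer chain, would move the number beyond the scatter also stays open.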